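A few compounds are considered here, and "the series" means these few. Any claim that something is new, unique, unknown or untested is made for them only; others in the source may bear on it.

Compound 1, `Cc1c(OCCCCOc2ccc(C(=O)O)cc2)ccc(C(=O)CC(C)C)c1O`: 95%
Compound 2, `Cc1c(OCCCCOc2cccc(C(=O)O)c2)ccc(C(=O)CC(C)C)c1O`: 100%
Compound 3, `Cc1c(OCCCCOc2ccc(C(=O)O)cc2F)ccc(C(=O)CC2CCCC2)c1O`: 97%

In an ADME assay on a cell-free system (plasma, Rattus norvegicus) for metabolic stability, read by LC-MS, with a stated time of 60 min, tested at 100 uM (on this read-out higher numbers stand for a more stable compound and lower numbers for a less stable compound), compound 3 stands second highest of the three numbers, but its gaps to compound 1 and to compound 2 are both within the scatter, so all three compounds look alike on this read-out. Compound 4, `Cc1c(OCCCCOc2ccc(C(=O)O)cc2F)ccc(C(=O)CC(C)C)c1O`, differs from compound 3 in one place: isopropyl in place of cyclopentyl on a saturated chain carbon bound to a carbonyl carbon. Going by the values given here, no measured step touches this part of the molecule. Among the compounds with values here, the only measured step, a number 5 percentage points higher from compound 1 to compound 2 (within the scatter), changes a different part and stays within the scatter. With every measured value high and close together, the step of a number 1 percentage points lower from compound 3 to compound 4 (within the scatter) is expected to be none beyond the scatter. Compound 4 is therefore estimated at 96%, with a range from 86% to 100%.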

Compound 4, percent of the compound remaining: 106%
Compound 4: middle estimate off by 10 percentage points, on the low side; measured number outside the range, above it.
By their numbers in this assay, from the lowest: compounds 1, 3, 2 and 4 (each within the scatter of the next, the first and the last beyond it).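

Isopropyl in place of cyclopentyl on a saturated chain carbon bound to a carbonyl carbon gives a number 9 percentage points higher from compound 3 to compound 4 (within the scatter) in this assay and so does not separate the two compounds. Fluoro in place of hydrogen on an aromatic carbon gives a number 11 percentage points higher from compound 1 to compound 4 (beyond the scatter) as the only modest step here beyond the scatter, while 4-carboxy-2-fluorophenyl in place of 3-carboxyphenyl gives a number 6 percentage points higher from compound 2 to compound 4 (within the scatter) and stays inside it. Nothing available accounts for these steps.
Still open, as far as these compounds go, is whether an amine or a longer chain on that chain carbon would leave the number as high, and whether chloro in place of fluoro would match the step seen with fluoro.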